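Enyne geometry at the alkyne terminus: Z versus E

A few compounds are considered here, and "the series" means these few. Any claim that something is new, unique, unknown or untested is made for them only; others in the source may bear on it.

Measured compounds:
- compound 1, `C/C=C\C#Cc1ccc(CCC(=O)O)c(F)c1`: 91%
- compound 2, `O=C(O)CCc1ccc(C#CC2CC2)cc1`: 128%

Both measurements come from a functional assay on 1321-N1 cells for agonist activity at Free fatty acid receptor 1 (Homo sapiens), read by calcium flux, with a stated time of 0.4 s; on this read-out lower numbers stand for smaller maximal responses and higher numbers for larger maximal responses. Compound 1 gives 91% in this assay and is the lower of the two numbers recorded. Among the measured compounds shown here, compound 2 gives 128% in this assay, a number that lies beyond the scatter above that of compound 1; the two compounds differ in more than one place, so no single-change step connects them and the gap is simply noted.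

Compound 3, `C/C=C/C#Cc1ccc(CCC(=O)O)c(F)c1`, has not yet been measured in this assay. Relative to compound 1 the change is the two compounds have the same atoms and bonds and differ only in configuration as drawn: 1 of 1 stereo elements differ; a double bond is drawn Z in compound 1 and E in compound 3. For the measured compounds named here, the series so far contains no pair that differs only in configuration, so there is no measured step to lean on for the size or direction of such a change. In the absence of that, the expected step from compound 1 to compound 3 is small, a number 4 percentage points higher from compound 1 to compound 3 (within the scatter), with no direction beyond the scatter assumed. Compound 3 is accordingly estimated at 95% in this assay, within a range from 70% to 125%.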

Compound 3, largest response reached (reported as efficacy), in percent of the reference or control that the assay uses: 97%
The estimate for compound 3 lay 2 percentage points below the measured number; measured number inside the range.
By their numbers in this assay, from the lowest: compounds 1 and 3 (each within the scatter of the next); then compound 2.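

Among the compounds shown here, the first pair that differs in configuration alone gives a direct reading of the double bond geometry in this assay, with a step of a number 6 percentage points higher from compound 1 to compound 3 (within the scatter). At this position, then, the maximal response does not separate the Z from the E double bond, at least within this pair and on this read-out. The reading is free of any other structural change, and the step can be assigned to geometry alone, although here it stays inside the scatter: the fact that compounds 1 and 3 differ only in the configuration as drawn

The pair speaks only to maximal response, so it leaves open whether Z and E geometry also match in the concentration needed to reach that response, and it offers no reason for the result. Also open, from the compounds shown here alone, is whether this tolerance of geometry carries over to other groups at the alkyne terminus, such as a longer chain bearing a hydroxyl group or an amine, where the configuration of a double bond could matter more or less than it does in this pair.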